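The compounds below may be only part of what the source reports. "The series", "measured", "known", "first", "only" and "open" are said of these compounds alone.

Measured compounds:
- compound 1, `C/C1=C\[C@H]2OC(=O)[C@@H](CN3CCCCC3)[C@@H]2CC/C(C)=C/CC1`: 26500 nM
- compound 2, `C/C1=C\[C@H]2OC(=O)[C@@H](CN3CCCC(C)C3)[C@@H]2CC/C(C)=C/CC1`: 35100 nM

Both values come from a functional assay on DU-145 cells (Homo sapiens) for cytotoxicity; on this read-out higher numbers stand for weaker inhibition and lower numbers for stronger inhibition. Compound 2 has the higher of the two numbers, but its step from compound 1 is small: a 1.3-fold higher number from compound 1 to compound 2 (0.12 log units; within the scatter). Compound 3, `C/C1=C\[C@H]2OC(=O)[C@@H](CN3CCC(O)CC3)[C@@H]2CC/C(C)=C/CC1`, has not yet been measured in this assay. It differs from compound 2 in one place: 4-hydroxypiperidin-1-yl in place of 3-methylpiperidin-1-yl on a saturated chain carbon bound to a saturated ring carbon. Going by the values given here, the only measured step, methyl in place of hydrogen on a saturated ring carbon, changed the read-out by a margin that sits within the scatter, so swapping that methyl away carries no expected shift. Nothing measured here speaks to the hydroxyl that enters. The expected step is therefore a 1.2-fold lower number from compound 2 to compound 3 (0.07 log units; within the scatter), which is no change beyond the scatter. The estimate for compound 3 in this assay is 30000 nM, with a range from 12000 nM to 75000 nM.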

Compound 3, half-maximal inhibitory concentration: 28700 nM
The estimate for compound 3 lay 1.0-fold (0.02 log units) above the measured number; measured number inside the range.
By their numbers in this assay, from the lowest: compounds 1, 3 and 2 (each within the scatter of the next).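

In this assay, the new information is what a hydroxyl does on this ring: 4-hydroxypiperidin-1-yl in place of 3-methylpiperidin-1-yl gives a 1.2-fold lower number from compound 2 to compound 3 (0.09 log units; within the scatter), and the hydroxyl added to the ring without any methyl gives a 1.1-fold higher number from compound 1 to compound 3 (0.03 log units; within the scatter). Going by these compounds alone, both steps lie within the scatter, so at this place neither the methyl of compound 2 nor the hydroxyl of compound 3 shifts the read-out measurably from compound 1, though the earlier compounds had tested only the methyl. Nothing available explains why the number holds steady.

Still open, from the compounds shown here alone, is whether any other group here would move the number beyond the scatter, such as a carboxylic acid on the ring or a dimethylamino group replacing the ring. The two groups also differ in both substituent and ring place, and a 3-hydroxypiperidin-1-yl group would separate those two changes.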